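Pyridine position and solubility in the series

This account rests on a few compounds, and the source may have more. Where it says the series, first, only, none or still open, it means among the compounds named here.

Measured in a physicochemical assay for solubility, read by LC-MS, in phosphate buffer, with a stated time of 20 min, at pH 7.0, tested at 100 uM; on this read-out higher numbers stand for higher solubility and lower numbers for lower solubility:
- compound 1 `COc1cc2c(cc1OC)CN(c1ccc(C=O)cc1)CC2`: 6600 nM
- compound 2 `COc1cc2c(cc1OC)CN(c1cccnc1)CC2`: 78900 nM
- compound 3 `COc1cc2c(cc1OC)CN(c1cc(C(F)(F)F)cc(C(F)(F)F)c1)CC2`: < 500 nM (a limit)

Compound 2 at 78900 nM holds the higher of the two numbers, and compound 1 at 6600 nM lies lower, beyond the scatter. The value of compound 3, < 500 nM, is a limit and not a number.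

Compound 4 `COc1cc2c(cc1OC)CN(c1ccccn1)CC2` carries pyridin-2-yl in place of pyridin-3-yl on an amine nitrogen in a ring. Among the compounds with values here, no measured pair shows this change directly. The expected step, a 2.3-fold lower number from compound 2 to compound 4 (0.35 log units; beyond the scatter), is a modest fall in this assay, slightly beyond the scatter. For compound 4 the estimate is 35000 nM, with an expected range of 12000 nM to 85000 nM.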

Compound 4, solubility: 800 nM
Compound 4: the middle estimate sits 44-fold (1.64 log units) above what was measured, outside the stated range (below it).
By their numbers in this assay, from the lowest: compound 4; then compound 1; then compound 2. At a limit, below all of these: compound 3.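

In this assay, pyridin-2-yl in place of pyridin-3-yl on an amine nitrogen in a ring brings a 99-fold lower number from compound 2 to compound 4 (1.99 log units; beyond the scatter) with the same atoms in both compounds. Within the data shown here, the arrangement of the pyridine alone therefore carries a large step, which compound 1, compound 2 and compound 3 could not show, as no pair among them differed in one place. Nothing shown here bears on the cause of this step.

Pyridin-4-yl lies outside the compounds shown, so it remains open whether pyridin-3-yl or pyridin-2-yl is the exception among the pyridine attachments.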